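A few compounds are considered here, and "the series" means these few. Any claim that something is new, unique, unknown or untested is made for them only; others in the source may bear on it.

Measured compounds:
compound 1, `CC(C)=CCn1c(CN2CCN(C(=O)C3CC3)CC2)nc2ccccc21`, 74.3%
compound 2, `Cc1cccc(Cn2c(CN3CCN(C(=O)c4cccnc4)CC3)nc3ccccc32)c1`, 24.5%
compound 3, `CCc1ccc(C(=O)N2CCN(Cc3nc4ccccc4n3Cc3cccc(C)c3)CC2)cc1`, 67%

These three compounds were tested in an assay on isolated protein for inhibition of aldehyde dehydrogenase 1A1 (Homo sapiens), read by spectrophotometry, tested at 10 uM; a higher number here means more inhibition at the concentration tested (going by the name of the read-out), a lower number less inhibition. Compound 1 gives the highest of the three numbers: compound 3 lies close to it, within the scatter, so the two cannot be ordered, while compound 2 lies far below both. Within the data shown here, the only step between compounds that differ in one place is a number 42.5 percentage points higher from compound 2 to compound 3 (beyond the scatter), a change on the carbonyl carbon.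

Compound 4, `O=C(C1CC1)N1CCN(Cc2nc3ccccc3n2Cc2ccccc2C(F)(F)F)CC1`, has not yet been measured in this assay. It differs from compound 1 in one place: 2-(trifluoromethyl)phenyl in place of 2-methylprop-1-en-1-yl on a saturated chain carbon bound to an aromatic nitrogen. Among the measured compounds shown here, this change sits on the saturated chain carbon bound to an aromatic nitrogen, a place where no measured step exists. For the measured compounds named here, the one measured step concerns the carbonyl carbon instead, so it does not bear directly on this change; it only shows that this shared core can give either low or high inhibition depending on what surrounds it. Compounds 2 and 3 both carry an aromatic ring at the place that changes here, and their values span a wide range. With no direct guide, compound 4 is expected to stay roughly near compound 1, with the step of a number 12.3 percentage points lower from compound 1 to compound 4 (beyond the scatter) estimated as not beyond the scatter, though the range is wide. The estimate for compound 4 is 62%, between 35% and 85%.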

Compound 4, a percentage reported as inhibition, at one concentration (the size of the read-out at that concentration, not a potency): 56.3%
Beside the measured number, compound 4's estimate is 5.7 percentage points above it; measured number inside the range.
By their numbers in this assay, from the lowest: compound 2; then compound 4; then compounds 3 and 1 (each within the scatter of the next).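

In this assay, the saturated chain carbon bound to an aromatic nitrogen now has its first measured step: putting 2-(trifluoromethyl)phenyl in place of 2-methylprop-1-en-1-yl gives a number 18 percentage points lower from compound 1 to compound 4 (beyond the scatter). This shows that the group at this position affects the read-out, yet an aromatic ring can replace an open chain with a double bond and compound 4 still gives 56.3% at the concentration tested, so this change does not abolish inhibition. Nothing available here accounts for the drop, so the reason for it stays unknown.

The compounds shown do not tell whether the drop belongs to the aromatic ring itself or to the trifluoromethyl group it carries, a question that a plain phenyl at this place, with the rest of compound 1 kept, could help to separate. Also open, going by these compounds, is how a longer saturated chain, an amine or a carboxylic acid at this same place would compare with the two groups measured so far.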